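Substituting the Amino Nitrogen of Compound 3

The source may hold more compounds than are shown below. What is called first, only, known or untested is meant among the compounds shown, and "the series" means these compounds.

In a functional assay on MOLT-4 cells (Homo sapiens) for cytotoxicity, read by trypan blue exclusion, with a stated time of 96 h (on this read-out higher numbers stand for weaker inhibition of growth and lower numbers for stronger inhibition of growth), compound 1 `COc1ccc(NS(=O)(=O)/C=C/c2c(OC)cc(OC)cc2OC)cc1` gives 100 nM, compound 2 `COc1cc(OC)c(/C=C/S(=O)(=O)Nc2ccc(OC)c(O)c2)c(OC)c1` gives 25 nM and compound 3 `COc1cc(OC)c(/C=C/S(=O)(=O)Nc2ccc(OC)c(N)c2)c(OC)c1` gives 8 nM. That last number is the lowest of the three, so compound 3 inhibits growth most strongly in this small set. Compound 4 `COc1cc(OC)c(/C=C/S(=O)(=O)Nc2ccc(OC)c(NC(C)(C)C(=O)O)c2)c(OC)c1` has not yet been measured. It is compound 3 with one change, 1-carboxy-1-methylethyl in place of hydrogen on a nitrogen on an aromatic ring.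

Three measured steps offer indirect guidance. Hydroxy in place of hydrogen gave a 4.0-fold lower number from compound 1 to compound 2 (0.60 log units; beyond the scatter), amino in place of hydrogen gave a 13-fold lower number from compound 1 to compound 3 (1.10 log units; beyond the scatter), and amino in place of hydroxy gave a 3.1-fold lower number from compound 2 to compound 3 (0.49 log units; beyond the scatter). These modest to large steps all lead toward lower numbers, with the amino compound at the low end. None of them, however, tests a group placed on that nitrogen, so the size of the new step remains uncertain. With compound 3 already at 8 nM, a move back toward weaker inhibition seems more likely than a further drop. The expected change is a modest one toward a higher number, a 3.8-fold higher number from compound 3 to compound 4 (0.57 log units; beyond the scatter). For compound 4 the estimated value is 30 nM, with an expected range from 8 nM to 150 nM.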

Compound 4, concentration for 50% growth inhibition: 30 nM
For compound 4 middle estimate and measured number coincide at the digits printed; the measured number falls inside the stated range.
By their numbers in this assay, from the lowest: compound 3; then compounds 2 and 4 (each within the scatter of the next); then compound 1.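

Placing 1-carboxy-1-methylethyl on the nitrogen on the aromatic ring of compound 3 gives, in this assay, a 3.8-fold higher number from compound 3 to compound 4 (0.57 log units; beyond the scatter) and so shows for the first time that this nitrogen can carry a substituent at a modest cost, since compound 4 still gives 30 nM in this test of growth inhibition. Replacing the hydroxy group with (1-carboxy-1-methylethyl)amino gives a 1.2-fold higher number from compound 2 to compound 4 (0.08 log units; within the scatter) which lies within the scatter, so the two compounds cannot be told apart, while the same group in place of hydrogen gives a 3.3-fold lower number from compound 1 to compound 4 (0.52 log units; beyond the scatter) and so keeps a real part of the gain seen with the free amino group. Nothing measured here explains why the substituent shifts the number as it does.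

The compounds shown leave open how a single methyl group on the same nitrogen would compare with the full 1-carboxy-1-methylethyl group, and so whether the carboxylic acid or the carbon framework accounts for the step. They also leave open how a methyl ester of this acid, or a longer chain ending in a carboxylic acid, would behave at this position.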